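Swapping a dimethylamino for a nitro on the shared core

The compounds below may be only part of what the source reports. "The series", "measured", "known", "first", "only" and "open" are said of these compounds alone.

Measured so far:
compound 1 `COc1ccc(-c2nc3c(=O)n(C)c(=O)n(C)c3[nH]2)cc1OC` gives 22.5 nM
compound 2 `CN(C)c1ccc(-c2nc3c(=O)n(C)c(=O)n(C)c3[nH]2)cc1` gives 1.8 nM
compound 3 `CN(C)c1cccc(-c2nc3c(=O)n(C)c(=O)n(C)c3[nH]2)c1` gives 80 nM

These three compounds were tested in an assay for binding affinity to adenosine receptor A1 (Bos taurus); a lower number here means a stronger inhibitor, a higher number a weaker inhibitor. Compound 2 stands lowest of the three numbers; compound 1 is the nearest to it and compound 3 the furthest, both gaps lying beyond the scatter. Compound 4 `Cn1c(=O)c2nc(-c3ccc([N+](=O)[O-])cc3)[nH]c2n(C)c1=O` has not yet been measured. It differs from compound 2 in one place: nitro in place of dimethylamino on an aromatic carbon. Going by the values given here, no measured pair in this set shows this particular change, so no measured step is available to copy. The two other compounds both sit well above compound 2, which makes a rise the more likely outcome. A step of an 8.3-fold higher number from compound 2 to compound 4 (0.92 log units; beyond the scatter) is expected here. Compound 4 is therefore estimated at 15 nM, within a range from 3 nM to 80 nM.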

Compound 4, half-maximal inhibitory concentration: 8 nM
Estimate against measurement, compound 4: 1.9-fold (0.27 log units) above; the measured number falls inside the stated range.
By their numbers in this assay, from the lowest: compound 2; then compound 4; then compound 1; then compound 3.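

In this assay, putting nitro in place of dimethylamino on this aromatic carbon gives a 4.4-fold higher number from compound 2 to compound 4 (0.65 log units; beyond the scatter), so the group at this place does affect the number. Going by these compounds alone, the step is modest, and compound 4 still reads 8 nM, so dimethylamino is not the only group that keeps the number low here. Nothing shown gives a reason for this step.

A single pair cannot set a trend for this position. Where a carboxylic acid or a plain methyl group at this place would fall remains open.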